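The compounds below may be only part of what the source reports. "The series", "measured", "known", "first", "only" and "open" are said of these compounds alone.

Measured so far in a functional assay on HEL cells (Homo sapiens) for inhibition; a higher number here means a weaker inhibitor, a lower number a stronger inhibitor:
- Compound 1 `CC(C)c1cc(-c2n[nH]c(=O)n2-c2cccc(C(=O)NCCCCCC(=O)NO)c2)c(O)cc1O` gives 4600 nM
- Compound 2 `CC(C)c1cc(-c2n[nH]c(=O)n2-c2cccc(NC(=O)CCCCC(=O)NO)c2)c(O)cc1O` gives 1600 nM

Of these two, compound 2 has the lower number and so is the stronger inhibitor, and the gap between them lies beyond the usual scatter of repeat measurements. The next compound to consider starts from compound 2. Compound 3 `CC(C)c1cc(-c2n[nH]c(=O)n2-c2cccc(C(=O)NCCCCC(=O)NO)c2)c(O)cc1O` has not yet been measured. It carries (4-(hydroxycarbamoyl)butyl)carbamoyl in place of ((4-(hydroxycarbamoyl)butyl)carbonyl)amino on an aromatic carbon. The two compounds have the same atoms, joined differently, so the counts on both sides of the swap match.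

Within the data shown here, no measured pair shows what this swap does on its own, so any expectation here is loose. Among the measured compounds shown here, the only other guide is compound 1 at 4600 nM, which points to a small rise at most rather than a fall. The expected change is a 1.6-fold higher number from compound 2 to compound 3 (0.19 log units; within the scatter), which would probably stay within the scatter. For compound 3 the estimated value in this assay is 2500 nM, with an expected range of 900 nM to 7000 nM.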

Compound 3, half-maximal inhibitory concentration: 4600 nM
Beside the measured number, compound 3's estimate is 1.8-fold (0.26 log units) below it, within the range that was stated.
By their numbers in this assay, from the lowest: compound 2; then compounds 1 and 3 (each within the scatter of the next).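

In this assay, putting (4-(hydroxycarbamoyl)butyl)carbamoyl in place of ((4-(hydroxycarbamoyl)butyl)carbonyl)amino on the aromatic carbon gives a clear loss of inhibition (a 2.9-fold higher number from compound 2 to compound 3 (0.46 log units; beyond the scatter)). Both groups hold the same atoms, joined differently, so this pair shows that the way the linker is joined to the ring matters at this position, which the two earlier compounds, differing in more than one place, could not show on its own. The other new comparison, hydroxycarbamoyl in place of (hydroxycarbamoyl)methyl on the saturated chain, leaves the number where it was (no change at the digits printed from compound 1 to compound 3 (within the scatter)), so this chain change within the carbamoyl-linked series has no visible effect, and nothing available explains either result.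

From the compounds shown here alone, it remains open whether the chain of the stronger ((4-(hydroxycarbamoyl)butyl)carbonyl)amino form would respond in the same way, for example with a longer chain. Going by these compounds, it is also open whether the link or the chain matters as much with a carboxylic acid at the end of the chain in place of the hydroxycarbamoyl group.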